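Replacing a Furan with a Bromophenyl at the Carbonyl

A few compounds are considered here, and "the series" means these few. Any claim that something is new, unique, unknown or untested is made for them only; others in the source may bear on it.

Compound 2 `O=C(/C=C/c1ccc2c(c1)B(O)OC2)c1ccco1` carries a furan-2-yl group on its carbonyl carbon. In a functional assay on SK-OV-3 cells (Homo sapiens) for cytotoxicity, read by MTT assay, with a stated time of 48 h (a lower number here means a stronger inhibitor, a higher number a weaker inhibitor), compound 2 gives 20700 nM, the highest number among the three measured compounds. Compound 1 `O=C(/C=C/c1ccc2c(c1)B(O)OC2)c1ccccc1`, with a plain phenyl in the same place, gives 3400 nM, and compound 3 `O=C(/C=C/c1ccc2c(c1)B(O)OC2)c1ccc(F)cc1`, with a 4-fluorophenyl, gives 1400 nM; the move a 15-fold lower number from compound 2 to compound 3 (1.17 log units; beyond the scatter) is the largest step seen here, and a 2.4-fold lower number from compound 1 to compound 3 (0.39 log units; beyond the scatter) shows that adding the fluoro on the aromatic carbon helps as well.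

Compound 4 `O=C(/C=C/c1ccc2c(c1)B(O)OC2)c1ccc(Br)cc1` has not yet been measured. The change from compound 2 is 4-bromophenyl in place of furan-2-yl on a carbonyl carbon. Since a six-membered carbon ring in place of the furan-2-yl gave a clear gain in both compound 1 and compound 3, a lower number is expected for compound 4 too, with bromo treated as roughly comparable to fluoro. The expected step is a 10-fold lower number from compound 2 to compound 4 (1.01 log units; beyond the scatter), and compound 4 is therefore estimated at 2000 nM, within a range from 700 nM to 6000 nM.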

Compound 4, half-maximal inhibitory concentration: 4500 nM
Beside the measured number, compound 4's estimate is 2.3-fold (0.35 log units) below it; the range from low to high includes it.
By their numbers in this assay, from the lowest: compound 3; then compounds 1 and 4 (each within the scatter of the next); then compound 2.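

A six-membered carbon ring on the carbonyl carbon still improves on the furan-2-yl when it carries a bromo, with a 4.6-fold lower number from compound 2 to compound 4 (0.66 log units; beyond the scatter), but this gain is smaller than the one seen with the 4-fluorophenyl of compound 3. In this assay, the two halogens are therefore not interchangeable on the aromatic carbon, as a 3.2-fold higher number from compound 3 to compound 4 (0.51 log units; beyond the scatter) shows, and a 1.3-fold higher number from compound 1 to compound 4 (0.12 log units; within the scatter) means that bromo cannot be told apart from hydrogen there, whereas fluoro gave a gain beyond the scatter. Nothing available gives a reason for the gap between bromo and fluoro.

The compounds shown leave open how a chloro, a methoxy or an amine on that aromatic carbon would compare. They also leave open how a saturated ring such as cyclohexyl on the carbonyl carbon would compare with the phenyl.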